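Amide substituent swap in a cytotoxicity series

This account rests on a few compounds, and the source may have more. Where it says the series, first, only, none or still open, it means among the compounds named here.

Of the compounds shown here, three of the shared core have been tested in a toxicity assay on HepG2 cells (Homo sapiens) for inhibition, read by CellTiter-Glo, with a stated time of 48 h; on this read-out lower numbers stand for stronger inhibition and higher numbers for weaker inhibition. Compound 1 `COc1cc2nc(C)cc(OCC(=O)Nc3cc(C)cc(C)c3)c2cc1OC` gives 10000 nM in this assay. Compound 3 `COc1ccc2nc(C)cc(OCC(=O)Nc3ccc(Cl)c(C(F)(F)F)c3)c2c1` gives 79400 nM in this assay. Compound 2 `COc1ccc2nc(C)cc(OCC(=O)Nc3cc(C)ccc3C)c2c1` gives only a limit of the assay, > 100000 nM, and no number; this is the limit of > 100000 nM in this assay, at which 1 of the 3 values shown sits. Among the measured compounds shown here, none of the three measured compounds differ from one another in a single place, so no measured step is available to lean on.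

Compound 4 `COc1ccc2nc(C)cc(OCC(=O)NC3CONC3=O)c2c1` has not yet been measured in this assay. Its difference from compound 2 is a group of 6 heavy atoms (3 carbon, 1 nitrogen, 2 oxygen; one five-membered non-aromatic ring with 2 hetero atoms) in place of a group of 8 heavy atoms (8 carbon; one six-membered aromatic ring of carbon only), on an amide-type nitrogen. For the measured compounds named here, with no single-change step measured in the set, the expected step from compound 2 to compound 4 in this assay is a number no higher from compound 2 to compound 4 (the limit leaves the size open), which means no change beyond the scatter, weak inhibition being retained. For compound 4 the estimated value in this assay is 100000 nM, with a range from 40000 nM to 300000 nM, and it is expected that the assay will most likely again report only a limit.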

Compound 4, half-maximal inhibitory concentration: > 100000 nM
Compound 4 gave a limit, no number (the forecaster's own chance of this, stated with the estimate: 70%); the middle value lies on the limit itself.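

Compound 2 and compound 4 each give only a limit and no number in this assay, so no step can be read between them: the limit of > 100000 nM in this assay, at which 2 of the 4 values shown sit.

Still open, on these data alone, is whether the 2,5-dimethylphenyl group and the five-membered non-aromatic ring on the amide-type nitrogen differ at all in inhibition.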